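A few compounds are considered here, and "the series" means these few. Any claim that something is new, unique, unknown or untested is made for them only; others in the source may bear on it.

Both measured members of the series sit at the assay limit. For compound 1 `Cc1ncsc1-c1ccc(CNC(=O)[C@@H]2C[C@@H](O)CN2C(=O)[C@@H](NC(=O)COCCOCCn2cc(CCOc3ccc(Cl)cc3C(=O)Nc3ccc([N+](=O)[O-])cc3Cl)nn2)C(C)(C)C)cc1`, in a functional assay on DU-145 cells (Homo sapiens) for inhibition, read by WST assay, with a stated time of 3 days (a lower number here means a stronger inhibitor, a higher number a weaker inhibitor), only a limit is known, > 10000 nM. For compound 2 `O=C(O)COCCOCCOc1ccc(Cl)cc1C(=O)Nc1ccc([N+](=O)[O-])cc1Cl`, in this assay likewise only a limit is known, > 10000 nM; this is the limit of > 10000 nM in this assay, at which 2 of the 2 values shown sit, so compound 2 stands at the limit rather than at a number. Compound 3 `C#CCCOc1ccc(Cl)cc1C(=O)Nc1ccc([N+](=O)[O-])cc1Cl` differs from compound 2 by ethynyl in place of 2-(carboxymethoxy)ethoxy on a saturated chain carbon, two bonds along the chain from an oxygen on an aromatic ring. Within the data shown here, no measured step covers such a change, so nothing beyond the scatter is expected in this assay; the step expected is a step that the limit leaves unreadable from compound 2 to compound 3. Compound 3 is expected at 15000 nM, between 3000 nM and 60000 nM, most likely again reported only as a limit.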

Compound 3, half-maximal inhibitory concentration: > 10000 nM
Compound 3: no number, only a limit (the forecaster's own chance of this, stated with the estimate: 80%); the middle value does not contradict the limit.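

No step can be read between compound 2 and compound 3, because both stand at the same limit: the limit of > 10000 nM in this assay, at which 3 of the 3 values shown sit. The compounds shown leave open how ethynyl and 2-(carboxymethoxy)ethoxy compare in this assay.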